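The compounds below may be only part of what the source reports. "The series", "measured", "known", "first", "only" and "open" are said of these compounds alone.

The series rests on a shared core, carried by compound 1 `COC(=O)C1=C(C)N=C(SC)NC1c1cccc([N+](=O)[O-])c1` and compound 2 `COC(=O)C1=C(C)N=C(SC)NC1c1ccccc1SC`. In an assay on Myocardium (Cavia porcellus) for displacement of a labelled ligand from Voltage-dependent L-type calcium channel subunit alpha-1C (Homo sapiens) (on this read-out higher numbers stand for weaker binding and lower numbers for tighter binding), compound 1 gives 480 nM, while compound 2 gives 1520 nM. For the measured compounds named here, of the two numbers known, compound 2 holds the higher one; its gap to compound 1 lies beyond the usual scatter, but since the two structures differ in more than one place, no single step accounts for that gap.

Compound 3 `COC(=O)C1=C(C)N=C(SC)NC1c1cccc([N+](=O)[O-])c1SC` has not yet been measured. It differs from compound 2 by one change: nitro in place of hydrogen on an aromatic carbon. Going by the values given here, compound 1 also carries a nitro group, and in this assay compound 1 gives 480 nM, the lower of the two numbers known, which is the only hint available. On that basis a downward step is expected, estimated at a 2.3-fold lower number from compound 2 to compound 3 (0.37 log units; beyond the scatter), though this direction rests on a single comparison that is itself not a clean step. For compound 3 the dissociation constant is therefore estimated at 650 nM, within a range from 200 nM to 2000 nM.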

Compound 3, dissociation constant: 30 nM
The estimate for compound 3 lay 22-fold (1.34 log units) above the measured number; measured number below the stated range.
By their numbers in this assay, from the lowest: compound 3; then compound 1; then compound 2.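

In this assay, for the compounds shown here, nitro in place of hydrogen on the aromatic carbon ortho to a methylsulfanyl group gives a 51-fold lower number from compound 2 to compound 3 (1.70 log units; beyond the scatter) and so marks this position as highly sensitive to this change, which the earlier compounds, differing in more than one place, could not show. Read from the other side, the added methylsulfanyl group gives a 16-fold lower number from compound 1 to compound 3 (1.20 log units; beyond the scatter) as a second large step, so among these compounds the tightest binding appears only where the nitro and methylsulfanyl groups stand together, as they do in compound 3, while compound 1 and compound 2 each carry just one of them. No measurement at hand bears on what lies behind these two steps.

From the compounds shown here alone, it remains open whether another group on this aromatic carbon, such as an amine or a nitrile, would give a step of similar size, or whether the nitro group is needed. Also open, going by these compounds, is whether a longer chain such as ethylsulfanyl could take the place of methylsulfanyl and still keep the binding this tight.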